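The source may hold more compounds than are shown below. What is called first, only, known or untested is meant among the compounds shown, and "the series" means these compounds.

Compound 1 `Cn1ncc(Cl)c1-c1cc(C(=O)N[C@@H]2CN[C@H](CCCO)C[C@H]2c2ccc(Cl)c(Cl)c2)oc1Cl` gives 510 nM in a functional assay on HCT-116 cells (Homo sapiens) for antiproliferative activity, read by sulforhodamine B assay, with a stated time of 72 h (on this read-out lower numbers stand for stronger inhibition and higher numbers for weaker inhibition), and none of the other numbers shown sits beyond the scatter from it: compound 3 `Cn1ncc(Cl)c1-c1cc(C(=O)N[C@@H]2CN[C@H](CC(=O)NC3CC3)C[C@H]2c2ccc(Cl)c(Cl)c2)oc1Cl` gives 740 nM and compound 2 `CC(=O)NCC[C@@H]1C[C@@H](c2ccc(F)c(F)c2)[C@H](NC(=O)c2cc(-c3c(Cl)cnn3C)c(Cl)o2)CN1` gives 920 nM. Compound 4 `Cn1ncc(Cl)c1-c1cc(C(=O)N[C@@H]2CN[C@H](CC(=O)NC3CCC3)C[C@H]2c2ccc(Cl)c(Cl)c2)oc1Cl` has not yet been measured. It differs from compound 1 by cyclobutylcarbamoyl in place of 2-hydroxyethyl on a saturated chain carbon bound to a saturated ring carbon. Among the measured compounds shown here, one measured step bears on this change, the one from the same hydroxyethyl chain to a three-membered carbamoyl ring, a 1.5-fold higher number from compound 1 to compound 3 (0.16 log units; within the scatter), which stays within the scatter. On that basis the four-membered ring is not expected to move the number by more than the scatter either. The expected step, a 1.4-fold higher number from compound 1 to compound 4 (0.14 log units; within the scatter), would not exceed the scatter. Compound 4 is therefore estimated at 700 nM, with a range from 350 nM to 1500 nM.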

Compound 4, half-maximal inhibitory concentration: 430 nM
Compound 4: the middle estimate sits 1.6-fold (0.21 log units) above what was measured; measured number inside the range.
By their numbers in this assay, from the lowest: compounds 4, 1, 3 and 2 (each within the scatter of the next, the first and the last beyond it).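

At this place, on a saturated chain carbon bound to a saturated ring carbon, cyclobutylcarbamoyl also holds the number in this assay within the scatter of the hydroxyl chain (a 1.2-fold lower number from compound 1 to compound 4 (0.07 log units; within the scatter)). Cyclobutyl in place of cyclopropyl on the amide-type nitrogen likewise shows no step beyond the scatter (a 1.7-fold lower number from compound 3 to compound 4 (0.24 log units; within the scatter)). No measurement here explains either result. The compounds shown leave open whether an amine or a carboxylic acid on this chain, or a cyclohexyl ring on the amide-type nitrogen, would stay within the scatter.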